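The source may report more compounds than this note shows. Statements on the series, on what has been measured and on what is new or still open speak of the compounds shown alone.

Measured compounds: compound 1 `C=C1CC[C@@H]2[C@](C)(CO[Si](C)(C)C(C)(C)C)[C@H](O)CC[C@@]2(C)[C@@H]1C/C=C1/C(=O)OC[C@H]1O` with 47 uM, compound 2 `C=C1CC[C@@H]2[C@](C)(CO[Si](c3ccccc3)(c3ccccc3)C(C)(C)C)[C@H](OC(C)=O)CC[C@@]2(C)[C@@H]1C/C=C1/C(=O)OC[C@H]1OC(C)=O` with 45.7 uM, compound 3 `C=C1CC[C@@H]2[C@](C)(CO[Si](C)(C)C(C)(C)C)[C@H](OC(C)=O)CC[C@@]2(C)[C@@H]1C/C=C1/C(=O)OC[C@H]1O` with 9.79 uM.

All three were tested in a functional assay on MCF7 cells (Homo sapiens) for cytotoxicity, read by sulforhodamine B assay; a higher number here means that more compound is needed for the effect, a lower number that less compound is needed. Compound 3 gives 9.79 uM, compound 1 gives 47 uM, and compound 2 gives 45.7 uM; the numbers for compound 1 and compound 2 lie within the scatter of each other. The change from compound 3 to compound 1 is hydrogen in place of acetyl on an oxygen on a saturated carbon, and it brought a 4.8-fold higher number from compound 3 to compound 1 (0.68 log units; beyond the scatter). Compound 4 `C=C1CC[C@@H]2[C@](C)(CO[Si](c3ccccc3)(c3ccccc3)C(C)(C)C)[C@H](O)CC[C@@]2(C)[C@@H]1C/C=C1/C(=O)OC[C@H]1OC(C)=O` carries the same change relative to compound 2, namely (hydrogen in place of acetyl on an oxygen on a saturated carbon), at the same place. The difference between the two cores, compound 2 against compound 3, is not broken down here. Because of a 4.8-fold higher number from compound 3 to compound 1 (0.68 log units; beyond the scatter) the expected step for compound 4 is a 3.3-fold higher number from compound 2 to compound 4 (0.52 log units; beyond the scatter). The estimate for compound 4 in this assay is 150 uM, between 40 uM and 400 uM.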

Compound 4, concentration for half-maximal effect: 9.63 uM
Estimate against measurement, compound 4: 16-fold (1.19 log units) above, and the stated range ends above it.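

Removing the acetyl, so that acetoxy becomes hydroxy, brought a 4.7-fold lower number from compound 2 to compound 4 (0.68 log units; beyond the scatter) in this assay. On the other core, the same change moved the number the opposite way, so its effect did not carry over from one core to the other: the same change on two cores in this assay, a 4.8-fold higher number (0.68 log units; beyond the scatter) from compound 3 to compound 1 and a 4.7-fold lower number (0.68 log units; beyond the scatter) from compound 2 to compound 4, 23-fold (1.36 log units) apart, beyond the scatter of two such steps This shows that, within these compounds, the outcome of the change depends on the core that carries it, but two pairs do not show which part of the core matters or why the direction reverses.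

Going by these compounds, it remains open how a longer acyl chain in place of the acetyl would behave on either core. On these data alone, it also remains open whether an amine in place of the hydroxy would follow either step.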